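A few compounds are considered here, and "the series" means these few. Any claim that something is new, unique, unknown or untested is made for them only; others in the source may bear on it.

Of the compounds shown here, two built on a shared core have so far been measured in an assay on isolated protein for activation of cGMP-dependent protein kinase 1 (Homo sapiens), read by ADP-Glo, with stated times of 30 min and 2 h, in the presence of a further agent that is not named here; a higher number here means that more compound is needed for the effect, a lower number that less compound is needed. Compound 1 `Cc1nc(C(=O)O)ccc1CN1CCC[C@H](O[C@H](CO)c2cc(Cl)cc(Cl)c2)[C@@H]1c1ccccc1` gives 370 nM in this assay. Compound 2 `COC(=O)Nc1cc(C(=O)O)ccc1CN1CCC[C@H](O[C@H](CO)c2cc(Cl)cc(Cl)c2)[C@@H]1c1ccccc1` gives 1000 nM in this assay, the higher of the two numbers; the gap between compound 1 and compound 2 lies beyond the usual scatter of repeated measurements. The next compound, compound 3 `Nc1cc(C(=O)O)ccc1CN1CCC[C@H](O[C@H](CO)c2cc(Cl)cc(Cl)c2)[C@@H]1c1ccccc1`, has not yet been measured in this assay. It differs from compound 2 in a single place: hydrogen in place of methoxycarbonyl on a nitrogen on an aromatic ring. For the measured compounds named here, no measured pair in this small set carries the same change, so the numbers at hand fix neither the size nor the direction of this step. The change is therefore expected to bring only a modest step of uncertain direction, a 1.4-fold lower number from compound 2 to compound 3 (0.15 log units; within the scatter). Compound 3 is expected to give about 700 nM in this assay, with a likely range from 250 nM to 2500 nM.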

Compound 3, half-maximal effective concentration: 290 nM
The estimate for compound 3 lay 2.4-fold (0.38 log units) above the measured number; the measured number falls inside the stated range.
By their numbers in this assay, from the lowest: compounds 3 and 1 (each within the scatter of the next); then compound 2.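

In this assay the loss of methoxycarbonyl from the nitrogen on the aromatic ring gives a 3.4-fold lower number from compound 2 to compound 3 (0.54 log units; beyond the scatter) and so shows that this position responds to what sits on that nitrogen, and that the methoxycarbonyl is not needed for the effect. For the compounds shown here, exchanging the whole group on the saturated chain carbon bound to an amine nitrogen in a ring gives a 1.3-fold lower number from compound 1 to compound 3 (0.11 log units; within the scatter) so the aromatic ring of carbon only that carries the amino group cannot be told apart here from the ring with 1 hetero atom in compound 1. Nothing measured here gives a reason for either step.

The compounds shown leave open whether the higher number belongs to the methoxycarbonyl alone or would also come with an acetyl or a methyl on the same nitrogen. They also leave open how a hydroxyl or a fluorine in place of the amino group would read in this assay on this ring.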